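Swapping Isopropyl for Benzyl on a Translocator Protein Ligand

The source may report more compounds than this note shows. Statements on the series, on what has been measured and on what is new or still open speak of the compounds shown alone.

Measured so far:
compound 1 `CCN(CC)C(=O)CN(Cc1ccccc1)c1cc(C)cc(C)c1` — 1010 nM
compound 2 `CCN(CC)C(=O)CN(Cc1ccc(OC(C)C)cc1)c1cc(C)cc(C)c1` — 2240 nM

Both numbers come from an assay on membranes from HEK293 cells for displacement of a labelled ligand from Translocator protein (Homo sapiens), read by scintillation counting, with a stated time of 90 min; on this read-out higher numbers stand for weaker inhibition and lower numbers for stronger inhibition. Compound 2 stands at the higher of the two, beyond the scatter from compound 1. Compound 3 `CCN(CC)C(=O)CN(Cc1ccc(OCc2ccccc2)cc1)c1cc(C)cc(C)c1` differs from compound 2 by benzyl in place of isopropyl on an oxygen on an aromatic ring. Going by the values given here, the only measured step that bears on this change is a 2.2-fold higher number from compound 1 to compound 2 (0.35 log units; beyond the scatter), in which the isopropoxy group first appeared. Since adding that group gave a 2.2-fold higher number from compound 1 to compound 2 (0.35 log units; beyond the scatter), a larger group in its place is expected to raise the number modestly again, a 1.6-fold higher number from compound 2 to compound 3 (0.19 log units; within the scatter). Compound 3 is therefore estimated at 3500 nM, with a range from 1200 nM to 10000 nM.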

Compound 3, inhibition constant: 433 nM
Beside the measured number, compound 3's estimate is 8.1-fold (0.91 log units) above it; measured number below the stated range.
By their numbers in this assay, from the lowest: compound 3; then compound 1; then compound 2.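

On the oxygen of this ring, the group decides the direction of the change: in this assay, benzyl in place of isopropyl gives a 5.2-fold lower number from compound 2 to compound 3 (0.71 log units; beyond the scatter) and makes compound 3 the lowest number of the three. Benzyloxy in place of hydrogen gives a 2.3-fold lower number from compound 1 to compound 3 (0.37 log units; beyond the scatter) while isopropoxy went the other way, so adding a group here does not always raise the number. Nothing available explains this reversal.

Two groups on this oxygen are too few to show a trend. As far as these compounds go, it remains open whether a longer chain such as phenethyl, or a benzyl ring carrying an amine, would lower the number further.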